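The source may hold more compounds than are shown below. What is called first, only, known or untested is meant among the compounds shown, and "the series" means these compounds.

Compounds 1, 2 and 3 share one core and differ only in the group on the aromatic ring that carries the benzylic amine. Compound 1 `Fc1ccc(CNc2nc(-c3ccccc3C(F)(F)F)nc3ccccc23)cc1` carries a fluoro there; in an assay on a protein complex for inhibition of ubiquitin carboxyl-terminal hydrolase 1/WD repeat-containing protein 48 (Homo sapiens), read by fluorescence (a lower number here means a stronger inhibitor, a higher number a weaker inhibitor), compound 1 gives 3400 nM. Compound 2 `FC(F)(F)c1ccccc1-c1nc(NCc2ccc(-c3ccccc3)cc2)c2ccccc2n1` carries a phenyl, and in this assay compound 2 gives 3700 nM. Compound 3 `FC(F)(F)c1ccccc1-c1nc(NCc2ccc(-c3ccc(Cl)c(Cl)c3)cc2)c2ccccc2n1` carries a 3,4-dichlorophenyl, and in this assay compound 3 gives 2200 nM. Compound 3 has the lowest of the three numbers, but the steps of a 1.5-fold lower number from compound 1 to compound 3 (0.19 log units; within the scatter) and a 1.7-fold lower number from compound 2 to compound 3 (0.23 log units; within the scatter) are both within the scatter, as is a 1.1-fold higher number from compound 1 to compound 2 (0.04 log units; within the scatter), so the three compounds are not separated.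

Compound 4 `FC(F)(F)c1ccccc1-c1nc(NCc2ccc(C3CCCCC3)cc2)c2ccccc2n1` is reached by cyclohexyl in place of 3,4-dichlorophenyl on an aromatic carbon. For the measured compounds named here, the three measured steps all exchange the group at this same place and none moved the number beyond the scatter, which is the only guide for this change. For compound 4 the expected step is therefore a 1.2-fold higher number from compound 3 to compound 4 (0.07 log units; within the scatter), in no direction beyond the scatter. The estimate for compound 4 in this assay is 2600 nM, with a range of 1000 nM to 7000 nM.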

Compound 4, half-maximal inhibitory concentration: 9800 nM
Beside the measured number, compound 4's estimate is 3.8-fold (0.58 log units) below it; measured number outside the range, above it.
By their numbers in this assay, from the lowest: compounds 3, 1 and 2 (each within the scatter of the next); then compound 4.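

Cyclohexyl is the first exchange at this position to move the number beyond the scatter in this assay, and compound 4 is the weakest of the four: the steps are a 4.5-fold higher number from compound 3 to compound 4 (0.65 log units; beyond the scatter) and a 2.6-fold higher number from compound 2 to compound 4 (0.42 log units; beyond the scatter) and a 2.9-fold higher number from compound 1 to compound 4 (0.46 log units; beyond the scatter). The position therefore tolerates fluoro, phenyl and 3,4-dichlorophenyl without separating them, but not every large group, and a non-aromatic six-membered ring of carbon only in place of an aromatic one is the change that goes with the higher number. No supporting data bear on what lies behind this shift.

Going by these compounds, whether the aromatic character of the ring matters, or something else that differs in cyclohexyl, stays open. A pyridine, a piperidine or a morpholine at this place would test how far the result extends beyond rings of carbon only.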